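A few compounds are considered here, and "the series" means these few. Any claim that something is new, unique, unknown or untested is made for them only; others in the source may bear on it.

In an ADME assay on microsomes from liver (Canis lupus familiaris) for metabolic stability (a lower number here means that the compound disappears faster, a higher number that the compound lasts longer), compound 1 `Nc1nc(NCCNc2ncc(-c3ncc[nH]3)c(-c3ccc(C(F)(F)F)cc3)n2)ccc1[N+](=O)[O-]` gives > 0.5 h, a limit and not a number. Compound 2 `Nc1nc(NCCNc2ncc(-c3ncc[nH]3)c(-c3ccc(F)cc3C(F)(F)F)n2)ccc1[N+](=O)[O-]` gives > 0.5 h, likewise only a limit, so it has no exact standing. Both compounds rest on the same line (the limit of > 0.5 h in this assay, at which 2 of the 2 values shown sit). Among the measured compounds shown here, the one measured step, a step that the two limits leave unreadable from compound 1 to compound 2, therefore has no size to carry forward. Compound 3 `Nc1nc(NCCNc2ncc(-c3ncc[nH]3)c(-c3cc(F)c(Cl)cc3F)n2)ccc1[N+](=O)[O-]` carries 4-chloro-2,5-difluorophenyl in place of 4-fluoro-2-(trifluoromethyl)phenyl on an aromatic carbon. For the measured compounds named here, with no sized step to go on, no direction can be argued, and no shift beyond the scatter is expected in this assay, an expected step that the limit leaves unreadable from compound 2 to compound 3. For compound 3 the estimated half-life is 0.7 h, with an expected range from 0.35 h to 1.5 h.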

Compound 3, half-life: > 0.5 h
Compound 3: only a limit was reported; the forecaster's own chance of this, stated with the estimate: 65%; the middle value is on the limit's open side.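

Compound 1, compound 2 and compound 3 all rest on one limit rather than a number, so no step among them can be read: the limit of > 0.5 h in this assay, at which 3 of the 3 values shown sit.

The compounds shown leave open their actual half-lives in this assay, and whether swapping these phenyl groups changes them at all.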